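The source may report more compounds than this note shows. Statements on the series, on what has been measured and on what is new or still open speak of the compounds shown alone.

Measured so far in a functional assay on A-427 cells (Homo sapiens) for cytotoxicity, read by colorimetric assay and MTT assay; on this read-out higher numbers stand for weaker inhibition and lower numbers for stronger inhibition

compound 1 `COc1ccc(-c2cc3c(OC)cc(OC)cc3n(CCCC#N)c2=O)cc1` gives 10000 nM
compound 2 `COc1ccc(-c2cc3c(OC)cc(OC)cc3n(CC(=O)O)c2=O)cc1` gives 10000 nM
compound 3 `COc1ccc(-c2cc3c(OC)cc(OC)cc3n(CCC(=O)OCc3ccccc3)c2=O)cc1` gives 10000 nM

All three compounds share one core and differ only in the substituent on the chain attached to the aromatic nitrogen. In this assay compound 3, at 10000 nM, stands level with compound 1 and compound 2 at the digits shown, so the series so far offers no spread in activity.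

The next structure is compound 4 `CCN(CC)C(=O)CCn1c(=O)c(-c2ccc(OC)cc2)cc2c(OC)cc(OC)cc21`, which has diethylamino in place of benzyloxy on a carbonyl carbon, so that benzyloxycarbonyl becomes diethylcarbamoyl diethylamino in place of benzyloxy on a carbonyl carbon and the rest of the molecule stays the same.

Going by the values given here, three measured steps bear on this change, all at the same end of the chain. They read no change at the digits printed from compound 1 to compound 2 (within the scatter), no change at the digits printed from compound 1 to compound 3 (within the scatter) and no change at the digits printed from compound 2 to compound 3 (within the scatter) in turn. Nitrile, carboxy and benzyloxycarbonyl ends thus gave the same reading, though no measured compound yet carries diethylcarbamoyl. On that evidence, no step beyond the scatter is expected in this assay, in either direction. The expected change is no change at the digits printed from compound 3 to compound 4 (within the scatter) as an estimate. Compound 4 is expected at 10000 nM, with an estimated range from 4000 nM to 20000 nM.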

Compound 4, half-maximal inhibitory concentration: 10000 nM
Compound 4: the middle estimate sits on the measured number at the digits printed; measured number inside the range.
By their numbers in this assay, from the lowest: compounds 1, 2, 3 and 4 (each within the scatter of the next).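

In this assay, diethylamino in place of benzyloxy on the carbonyl carbon gives no change at the digits printed from compound 3 to compound 4 (within the scatter), so losing the benzyloxy aromatic ring and bringing in a nitrogen at this carbonyl does not shift the reading. With diethylcarbamoyl in place, the chain end now includes an amide, and the comparisons with the other two chain ends read no change at the digits printed from compound 2 to compound 4 (within the scatter) and no change at the digits printed from compound 1 to compound 4 (within the scatter), which leaves the nitrile, carboxy, benzyloxycarbonyl and diethylcarbamoyl ends all level at the digits printed on the shared core. Nothing available explains why the reading stays the same across these four ends.

The compounds shown leave open whether any group on this chain can move the reading at all, for instance a primary amine at the chain end, a morpholine amide in place of diethylamino, or a longer chain. They also leave open whether the reading responds to a change elsewhere on the shared core, such as a hydroxyl in place of a methoxy group.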